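This account rests on a few compounds, and the source may have more. Where it says the series, first, only, none or still open, it means among the compounds named here.

Series notes. Compound 1 `Nc1ncnc2c1ccn2-c1ccc(NC(=O)c2cccc(C(F)(F)F)c2)cc1` is the reference point. In an ADME assay on HS27 cells (Homo sapiens) for antiproliferative activity, read by MTT assay, with a stated time of 24 h (a lower number here means a stronger inhibitor, a higher number a weaker inhibitor), compound 1 gives 7100 nM. Among the values recorded in this assay this is the only one that is a number; the one other entry is a limit. That entry belongs to compound 2 `Nc1ncnc2c1ccn2-c1ccc(NC(=O)Nc2ccc(Cl)c(C(F)(F)F)c2)cc1`, which in this assay gives > 10000 nM, a limit of the assay and not a number (the limit of > 10000 nM in this assay, at which 1 of the 2 values shown sits). Among the compounds with values here, compound 2 differs from compound 1 in more than one place, so no single step can be drawn between them, and nothing beyond the two values themselves is stated for that pair.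

Compound 3 `Nc1ncnc2c1ccn2-c1ccc(NC(=O)c2ccc(Cl)c(C(F)(F)F)c2)cc1` has not yet been measured. It differs from compound 1 by chloro in place of hydrogen on an aromatic carbon. Within the data shown here, no measured step of this kind exists within the set, so the expectation for the size of the change in this assay rests on no measured pair here; the expectation is for a step no larger than the usual scatter, in neither direction in particular. The step from compound 1 to compound 3 is expected to be a 1.1-fold higher number from compound 1 to compound 3 (0.05 log units; within the scatter). For compound 3 the estimate in this assay is 8000 nM, with a range from 3000 nM to 20000 nM.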

Compound 3, half-maximal inhibitory concentration: 5600 nM
Compound 3: the middle estimate sits 1.4-fold (0.15 log units) above what was measured, and the stated range covers the measured number.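

In this assay, within the data shown here, chloro in place of hydrogen on an aromatic carbon, ortho to a trifluoromethyl group and para to a large group, gives the first single-place step: a 1.3-fold lower number from compound 1 to compound 3 (0.10 log units; within the scatter). Among these compounds, this position on the six-membered aromatic ring therefore accepts a chloro with no change beyond the scatter in this assay, and the amide series now holds two numbers, where the earlier compounds offered only one number and one limit. Nothing on hand bears on why the step has this size.

On these data alone, a single substituent at a single position says little about the position in general, so it remains open how a methoxy, an amine, a nitrile or a carboxylic acid in place of the chloro would read in this assay, and whether any of them would move the number beyond the scatter. Among the compounds shown here, compound 2 remains a limit and not a number, and no step to it can be read: the limit of > 10000 nM in this assay, at which 1 of the 3 values shown sits.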